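A few compounds are considered here, and "the series" means these few. Any claim that something is new, unique, unknown or untested is made for them only; others in the source may bear on it.

Values measured in a functional assay on MCF7 cells (Homo sapiens) for antiproliferative activity, read by CellTiter-Glo, with a stated time of 5 days; on this read-out higher numbers stand for weaker inhibition and lower numbers for stronger inhibition:
- compound 1 `CC/C(=C(/c1ccc(/C=C/C(=O)O)cc1)c1ccn2ccnc2c1)c1ccccc1`: > 500 nM, a limit of the assay and not a number
- compound 2 `CC/C(=C(/c1ccc(/C=C/C(=O)O)cc1)c1ccc2scnc2c1)c1ccccc1`: 90 nM
- compound 3 `O=C(O)/C=C/c1ccc(/C(=C(\c2ccccc2)C2CCC2)c2ccc3scnc3c2)cc1`: 16 nM

Among the compounds with actual numbers, compound 3 has the lower one, and the only other number belongs to compound 2. The next compound, compound 4 `O=C(O)/C=C/c1ccc(/C(=C(\c2ccc(C(F)(F)F)cc2Cl)C2CCC2)c2ccc3scnc3c2)cc1`, departs from compound 3 in a single place: 2-chloro-4-(trifluoromethyl)phenyl in place of phenyl on a double-bonded chain carbon bound to a double-bonded chain carbon and a saturated ring carbon. In words, 2-chloro-4-(trifluoromethyl)phenyl stands in place of phenyl on a double-bonded chain carbon bound to a double-bonded chain carbon and a saturated ring carbon.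

Among the measured compounds shown here, no measured step has altered this phenyl, so the evidence is indirect. For the measured compounds named here, the closest precedent is the exchange of ethyl for cyclobutyl on that same carbon, a 5.6-fold lower number from compound 2 to compound 3 (0.75 log units; beyond the scatter). The earlier change of the other aromatic group gave an at least 5.5-fold lower number from compound 1 to compound 2 (0.74 log units; beyond the scatter). Both moved the number downward, and the series has so far responded to single changes by amounts beyond the scatter. A further decrease of similar or smaller size is therefore expected in this assay, though a result within the scatter of compound 3 would not be surprising. The estimated step is a 2.3-fold lower number from compound 3 to compound 4 (0.36 log units; beyond the scatter). For compound 4 the expected value is 7 nM, with an estimated range from 2 nM to 30 nM.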

Compound 4, half-maximal inhibitory concentration: 2.6 nM
For compound 4 the middle estimate is 2.7-fold (0.43 log units) above the measured one, within the range that was stated.
By their numbers in this assay, from the lowest: compound 4; then compound 3; then compound 2. At a limit, above all of these: compound 1.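

In this assay, the phenyl on the double-bonded chain carbon bound to a double-bonded chain carbon and a saturated ring carbon is shown for the first time to be a place where a change moves the number: 2-chloro-4-(trifluoromethyl)phenyl in place of phenyl gives a 6.2-fold lower number from compound 3 to compound 4 (0.79 log units; beyond the scatter). Among the compounds shown here, the entering group has 11 heavy atoms against 6 for the phenyl, so this position accepts a clearly larger substituted aromatic group while the number still falls, and all three single changes have now lowered the number by amounts beyond the scatter, with no compound going against this. Nothing among the measurements offered here explains why this exchange lowers the number.

The compounds shown leave open whether the chlorine or the trifluoromethyl group carries the step, as the two enter together and neither appears alone on this phenyl. They also leave open how the number would respond to a methoxy group or a nitrile on this ring, or to a primary amide in place of the carboxylic acid.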